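The source may hold more compounds than are shown below. What is called first, only, known or untested is meant among the compounds shown, and "the series" means these compounds.

Of the compounds shown here, three from the same series have been tested in an ADME assay on Vero cells (Chlorocebus sabaeus) for cytotoxicity, with a stated time of 7 days; on this read-out higher numbers stand for lower toxicity in this test and lower numbers for higher toxicity in this test. Compound 1 `COc1ccc2[nH]c(C(=O)N3CC(=O)N(Cc4ccc[nH]4)[C@@H](Cc4ccccc4)C3)cc2c1` gives 15200 nM in this assay. Compound 2 `COc1cccc(CN2C(=O)CN(C(=O)c3cc4cc(OC)ccc4[nH]3)C[C@@H]2CC2CCCCC2)c1` reaches only a limit of the assay, > 10000 nM, and no number is known for it. Compound 3 `COc1ccc2[nH]c(C(=O)N3CC(=O)N(Cc4ccccc4)[C@@H](COC(C)(C)C)C3)cc2c1` gives 78200 nM, which is the highest of the two numbers on hand; the nearest is the value of compound 1, and the gap between them lies beyond the scatter. The remaining value, as noted, is the limit of > 10000 nM in this assay, at which 1 of the 3 values shown sits, and not a number.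

The step now followed leads from compound 3 to compound 4 `COc1ccc2[nH]c(C(=O)N3CC(=O)N(Cc4ccccc4)[C@@H](CN4CCCc5ccccc54)C3)cc2c1`, which has not yet been measured in this assay. The change is 1,2,3,4-tetrahydroquinolin-1-yl in place of tert-butoxy on a saturated chain carbon bound to a saturated ring carbon. Going by the values given here, no step between two measured compounds of this set shows a change of this kind, so the size of the step must be estimated from the structures alone. The larger entering group is expected to bring the number down, and the expected step is a 3.9-fold lower number from compound 3 to compound 4 (0.59 log units; beyond the scatter). Compound 4 is therefore expected to give about 20000 nM in this assay, with a likely range from 6000 nM to 60000 nM.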

Compound 4, half-maximal cytotoxic concentration: > 100000 nM
Compound 4: only a limit was reported; the forecaster's own chance of this, stated with the estimate: 25%; at least 5.0-fold (0.69 log units) between middle value and limit.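

In this assay compound 4 reaches only a limit, > 100000 nM, and not a number. The change therefore reads as an at least 1.2-fold higher number from compound 3 to compound 4 (0.10 log units; that floor lies within the scatter), a floor rather than a measured size. Going by these compounds alone, it is the first comparison in this set between compounds that differ in one place, and it shows that putting 1,2,3,4-tetrahydroquinolin-1-yl in place of tert-butoxy, on a saturated chain carbon bound to a saturated ring carbon, brought no fall in the number, even though the entering group is larger and carries two rings.

As far as these compounds go, how far the true value of compound 4 lies past its limit remains open. Also open, from the compounds shown here alone, is whether a smaller group at this place, such as a simple dimethylamino group or a carboxylic acid, would leave the number equally high.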